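This account rests on a few compounds, and the source may have more. Where it says the series, first, only, none or still open, it means among the compounds named here.

Measured so far:
- compound 1, `CN(C)C(=O)CN1CCC(c2cc3c(-c4ccc(=O)n(C5CCOCC5)c4)ccnc3[nH]2)CC1`: 1.1
- compound 2, `CC(C)Cn1cc(-c2ccnc3[nH]c(C4CCN(CC(=O)N(C)C)CC4)cc23)ccc1=O`: 2
- compound 3, `COc1cc(F)ccc1-c1ccnc2[nH]c(C3CCN(CC(=O)N(C)C)CC3)cc12`: 2.9

All three share one core and were measured in a physicochemical assay for lipophilicity, using the shake flask method, measured as octanol-water partition, at pH 7.4; a lower number here means a more polar compound, a higher number a more lipophilic compound. Compound 3 stands highest of the three: compound 2 gives 2 and compound 1 gives 1.1, both well separated from the value of compound 3, which is 2.9.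

Compound 4, `CC(C)n1cc(-c2ccnc3[nH]c(C4CCN(CC(=O)N(C)C)CC4)cc23)ccc1=O`, has not yet been measured. It differs from compound 3 in one place: a group of 10 heavy atoms (8 carbon, 1 nitrogen, 1 oxygen; one six-membered aromatic ring with 1 hetero atom) in place of a group of 9 heavy atoms (7 carbon, 1 oxygen, 1 fluorine; one six-membered aromatic ring of carbon only), on an aromatic carbon.

Going by the values given here, only one measured step exists, a number 0.90 log units higher from compound 1 to compound 2 (beyond the scatter), where isobutyl replaced oxan-4-yl on an aromatic nitrogen. Compound 2 carries a ring of the same kind as the group entering in compound 4, but with isobutyl on its nitrogen, so compound 2 is the closest guide. The number for compound 4 is therefore expected to fall clearly below compound 3 and a little below compound 2, giving an estimated step of a number 1.20 log units lower from compound 3 to compound 4 (beyond the scatter). Compound 4 is estimated at 1.7, with a range from 1.3 to 2.1.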

Compound 4, distribution coefficient: 1.9
The estimate for compound 4 lay 0.20 log units below the measured number, within the range that was stated.
By their numbers in this assay, from the lowest: compound 1; then compounds 4 and 2 (each within the scatter of the next); then compound 3.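

In this assay, replacing 4-fluoro-2-methoxyphenyl on this aromatic carbon, opposite the ring nitrogen, with the ring carrying isopropyl on its nitrogen gives a number 1.00 log units lower from compound 3 to compound 4 (beyond the scatter). Isopropyl and isobutyl on that aromatic nitrogen cannot be told apart, with a number 0.10 log units lower from compound 2 to compound 4 (within the scatter), whereas isopropyl in place of oxan-4-yl gives a number 0.80 log units higher from compound 1 to compound 4 (beyond the scatter), so compounds 2 and 4, with their open-chain groups, both stand clear of compound 1 with its oxan-4-yl ring. No measurement shown here explains these differences.

The compounds shown leave open where a methyl group or a longer chain such as hexyl on that aromatic nitrogen would fall. They also leave open whether an amine or a carboxylic acid on that substituent would bring the number near or under that of compound 1.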